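Swapping the aryl group on the triazole in a spiro series

This account rests on a few compounds, and the source may have more. Where it says the series, first, only, none or still open, it means among the compounds named here.

Measured compounds:
compound 1, `N#CC1=C(N)Oc2c(c3nc4ccccc4nc3c3ccccc23)C12C(=O)N(Cc1cnnn1-c1ccc(F)cc1)c1ccccc12`: > 50000 nM
compound 2, `N#CC1=C(N)Oc2c(N)cc3nc4ccccc4nc3c2C12C(=O)N(Cc1cnnn1-c1ccccc1Br)c1ccccc12`: 27400 nM

Both compounds were tested in a functional assay on A549 cells (Homo sapiens) for antiproliferative activity, read by MTT assay, with a stated time of 48 h; a higher number here means a weaker inhibitor, a lower number a stronger inhibitor. For compound 1 the result is a limit of the assay rather than a number, (the limit of > 50000 nM in this assay, at which 1 of the 2 values shown sits). For the measured compounds named here, compound 2 is the only one of the pair with a measured number, which places it as the single firm value in the set. Compound 3, `Cc1ccc(-n2nncc2CN2C(=O)C3(C(C#N)=C(N)Oc4c(N)cc5nc6ccccc6nc5c43)c3ccccc32)cc1C`, has not yet been measured. It differs from compound 2 in one place, (3,4-dimethylphenyl in place of 2-bromophenyl on an aromatic nitrogen), that is, 3,4-dimethylphenyl in place of 2-bromophenyl on an aromatic nitrogen. Going by the values given here, no measured pair in this set isolates such a change, so no direction can be drawn from the data. Compound 3 is therefore expected to sit close to compound 2, with a step of a 1.1-fold higher number from compound 2 to compound 3 (0.04 log units; within the scatter) that stays within the usual scatter. The estimate for compound 3 is 30000 nM, with a range from 9000 nM to 80000 nM.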

Compound 3, half-maximal inhibitory concentration: > 50000 nM
Compound 3 ended at the assay's limit; the forecaster's own chance of this, stated with the estimate: 35%; middle value at least 1.6-fold (0.22 log units) away from the limit.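

In this assay compound 3 gives > 50000 nM, which is a limit of the assay and not a number. For the compounds shown here, putting 3,4-dimethylphenyl in place of 2-bromophenyl on an aromatic nitrogen yields the first step that can be read at this position, an at least 1.8-fold higher number from compound 2 to compound 3 (0.26 log units; that floor lies within the scatter); only a floor is known and it lies within the scatter, so the change shows no gain in strength but cannot be called a loss. Firm comparisons at this position remain scarce: the limit of > 50000 nM in this assay, at which 2 of the 3 values shown sit.

As far as these compounds go, how far compound 3 truly lies from compound 2 stays open, as does whether the bromine itself matters. A plain phenyl ring, or a methoxy group or a carboxylic acid on that ring, could show whether this position can give a stronger compound.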